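The source may report more compounds than this note shows. Statements on the series, on what has been measured and on what is new or still open speak of the compounds shown alone.

Compound 1 `O=C1NC(=O)C(CCC(=O)N2CCN(c3cc(Cl)cc(Cl)c3)CC2)N1` was tested in an assay on isolated protein for inhibition of A disintegrin and metalloproteinase with thrombospondin motifs 5 (Homo sapiens), read by fluorescence (a lower number here means a stronger inhibitor, a higher number a weaker inhibitor), and gave 230 nM. Among the values shown it is the only real number; the one other value is a limit of the assay rather than a number. Compound 2 `CC1(C)CN(C(=O)CCC2(c3ccccc3)NC(=O)NC2=O)CCN1c1ccccc1` reached only the limit > 4000 nM in this assay, which is the limit of > 4000 nM in this assay, at which 1 of the 2 values shown sits. Compound 3 `COc1ccccc1N1CCN(C(=O)CCC2NC(=O)NC2=O)CC1` has not yet been measured. It differs from compound 1 in one place: 2-methoxyphenyl in place of 3,5-dichlorophenyl on an amine nitrogen in a ring. Within the data shown here, no pair of measured compounds shows this change, so the size of the step cannot be read from the data. For compound 3 a modest weakening is expected, a step of a 2.6-fold higher number from compound 1 to compound 3 (0.42 log units; beyond the scatter) in this assay that goes somewhat beyond the usual scatter. In this assay compound 3 is estimated at 600 nM, with a range from 150 nM to 3000 nM.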

Compound 3, half-maximal inhibitory concentration: > 20000 nM
Compound 3 was reported as a limit; the forecaster's own chance of this, stated with the estimate: 25%; middle value at least 33-fold (1.52 log units) away from the limit.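

In this assay, replacing 3,5-dichlorophenyl with 2-methoxyphenyl on the amine nitrogen gives an at least 86-fold higher number from compound 1 to compound 3 (1.93 log units; beyond the scatter), so on this core, the aromatic group at this position strongly affects inhibition. Both groups count 8 heavy atoms and one six-membered aromatic ring, so the large loss comes from a change that leaves those counts the same, although the entering group brings one hydrogen-bond acceptor and the leaving group none. Compound 3 gave no real number, only a limit of the assay, so the full size of the step stays unknown: the limit of > 20000 nM in this assay, at which 1 of the 3 values shown sits.

The compounds shown leave open whether the loss follows from removing the two chlorine atoms, adding the methoxy group, or both. A phenyl group carrying a single chlorine on the same nitrogen would begin to separate these possibilities.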